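The compounds below may be only part of what the source reports. "The series", "measured", "known", "first", "only" and "open" are said of these compounds alone.

Compound 1 `O=C1NC(c2ccccc2)CN1S(=O)(=O)c1ccc2c(c1)CCCN2` — > 20000 nM
Compound 2 `COC(=O)N1CCCc2cc(S(=O)(=O)N3CC(c4ccccc4)NC3=O)ccc21` — > 20000 nM
Compound 3 `CC(C)COC(=O)N1CCCc2cc(S(=O)(=O)N3CC(c4ccccc4)NC3=O)ccc21` — 2380 nM

All three share the same core and differ only at a nitrogen on an aromatic ring in a ring. In a functional assay on K562 cells (Homo sapiens) for antiproliferative activity, read by MTT assay (a higher number here means a weaker inhibitor, a lower number a stronger inhibitor), compound 1 gives > 20000 nM, which is a limit of the assay and not a number. Compound 1 therefore sits at the limit of > 20000 nM in this assay, at which 2 of the 3 values shown sit. Compound 2 is also at a limit, so a step that the two limits leave unreadable from compound 1 to compound 2. By contrast, an at least 8.4-fold lower number from compound 1 to compound 3 (0.92 log units; beyond the scatter), and an at least 8.4-fold lower number from compound 2 to compound 3 (0.92 log units; beyond the scatter), showing that a larger ester group on that nitrogen does bring the number down into the readable range.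

Compound 4 `O=C(OCCCl)N1CCCc2cc(S(=O)(=O)N3CC(c4ccccc4)NC3=O)ccc21` carries (2-chloroethoxy)carbonyl in place of hydrogen on a nitrogen on an aromatic ring in a ring. The entering group is longer than methoxycarbonyl but smaller than isobutoxycarbonyl, so it lies between the two measured changes, one of which stayed at the limit and one of which gave an at least modest drop. A smaller step than that seen for compound 3 is therefore expected, namely an at least 2.2-fold lower number from compound 1 to compound 4 (0.34 log units; beyond the scatter). For compound 4 the expected value is 9000 nM, in a range from 2500 nM to 30000 nM, with a real chance that only a limit is reported.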

Compound 4, half-maximal inhibitory concentration: 10600 nM
For compound 4 the middle estimate is 1.2-fold (0.07 log units) below the measured one, and the stated range covers the measured number.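

Among these compounds, the (2-chloroethoxy)carbonyl group shows that isobutoxycarbonyl is not the only group on this nitrogen to give a readable number in this assay, but its gain can be stated only as a floor: an at least 1.8-fold lower number from compound 1 to compound 4 (0.27 log units; that floor lies within the scatter), and an at least 1.8-fold lower number from compound 2 to compound 4 (0.27 log units; that floor lies within the scatter). Those two steps start from a limit of the assay and not from a number: the limit of > 20000 nM in this assay, at which 2 of the 4 values shown sit. The more informative comparison has a measured number at both ends, and it shows that the entering group matters at this position, with a 4.5-fold higher number from compound 3 to compound 4 (0.65 log units; beyond the scatter) when chloromethyl takes the place of isopropyl on the chain.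

The compounds shown leave open whether this step goes with the chlorine or with the isopropyl end of the chain, and a plain ethoxycarbonyl or propoxycarbonyl group would help to separate the two. Also open, from the compounds shown here alone, is whether the number keeps falling with a longer chain such as hexyloxycarbonyl, or with a ring-bearing group such as benzyloxycarbonyl.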